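From fluoro to nitro on compound 3

The source may report more compounds than this note shows. Statements on the series, on what has been measured and on what is new or still open speak of the compounds shown alone.

In an ADME assay on Vero cells (Chlorocebus sabaeus) for cytotoxicity, read by resazurin assay, with a stated time of 72 h (a higher number here means a weaker inhibitor, a lower number a stronger inhibitor), compound 1 (`COc1ccc(C(=O)CCN2CCN(c3ccc(F)cc3)CC2)cc1`) gives 55000 nM and compound 2 (`COc1ccc(C(=O)CCN2CCN(c3ccc(C(F)(F)F)cc3)CC2)cc1`) gives 135000 nM while compound 3 (`COc1ccc(C(=O)CCN2CCN(c3ccc(F)cc3)CC2)cc1OC`) gives 175000 nM so compound 3 lies within the usual scatter of compound 2. Compound 4 (`COc1ccc(C(=O)CCN2CCN(c3ccc([N+](=O)[O-])cc3)CC2)cc1OC`) has nitro in place of fluoro on an aromatic carbon of compound 3 (nitro in place of fluoro on an aromatic carbon). The closest measured change also replaces fluoro, by trifluoromethyl, and gave a modest step (a 2.5-fold higher number from compound 1 to compound 2 (0.39 log units; beyond the scatter)). Adding methoxy gave another modest step (a 3.2-fold higher number from compound 1 to compound 3 (0.50 log units; beyond the scatter)) but bears less directly. Among the compounds with values here, no measured compound carries nitro, so only a small rise is expected in this assay and the estimated step is a 1.1-fold higher number from compound 3 to compound 4 (0.04 log units; within the scatter) with no clear change likely. Compound 4 is estimated at 190000 nM with 70000 nM to 400000 nM as the expected range.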

Compound 4, half-maximal inhibitory concentration: 105000 nM
Beside the measured number, compound 4's estimate is 1.8-fold (0.26 log units) above it; the measured number falls inside the stated range.
By their numbers in this assay, from the lowest: compounds 1, 4, 2 and 3 (each within the scatter of the next, the first and the last beyond it).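

In this assay, replacing fluoro with nitro on the aromatic ring of compound 3 brings in more heavy atoms and two hydrogen-bond acceptors, yet the step (a 1.7-fold lower number from compound 3 to compound 4 (0.22 log units; within the scatter)) shows no clear change. The earlier fluoro replacement, by trifluoromethyl (a 2.5-fold higher number from compound 1 to compound 2 (0.39 log units; beyond the scatter)), went beyond the scatter, but on a core with one methoxy fewer. Nothing available accounts for this difference.

On these data alone, it remains open whether nitro would behave the same way on the core of compound 1, and whether an amine or a carboxylic acid at this position would shift the number.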